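This account rests on a few compounds, and the source may have more. Where it says the series, first, only, none or still open, it means among the compounds named here.

Among the measured compounds shown here, compound 1 `Cc1cc(OCc2nc3ccccc3s2)ccc1NC(=O)Nc1ccc(Cl)c(Cl)c1` gives the lowest of the two numbers so far in an assay on isolated protein for inhibition of Polyunsaturated fatty acid 5-lipoxygenase (Homo sapiens), read by HPLC, with a stated time of 10 min (a lower number here means a stronger inhibitor, a higher number a weaker inhibitor), where compound 1 shows 230 nM. Compound 2 `Cc1cc(OCc2nc3ccccc3s2)ccc1NC(=O)Nc1ccccc1Cl` is weaker, with compound 2 at 830 nM, a step of a 3.6-fold higher number from compound 1 to compound 2 (0.56 log units; beyond the scatter). Compound 3 `Cc1cc(OCc2nc3ccccc3s2)ccc1NC(=O)Nc1cc(Cl)cc(Cl)c1` differs from compound 1 by 3,5-dichlorophenyl in place of 3,4-dichlorophenyl on an amide-type nitrogen. For the measured compounds named here, only the step from compound 1 to compound 2 touches this ring, and it shows that the pattern of chlorines there matters, so a modest loss is expected for compound 3, the estimated step being a 1.7-fold higher number from compound 1 to compound 3 (0.24 log units; within the scatter). Compound 3 is therefore expected to give about 400 nM, plausibly between 150 nM and 1000 nM.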

Compound 3, half-maximal inhibitory concentration: 80 nM
The estimate for compound 3 lay 5.0-fold (0.70 log units) above the measured number; measured number below the stated range.
By their numbers in this assay, from the lowest: compound 3; then compound 1; then compound 2.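

With the same atoms joined differently, 3,5-dichlorophenyl in place of 3,4-dichlorophenyl on the amide-type nitrogen gives a 2.9-fold lower number from compound 1 to compound 3 (0.46 log units; beyond the scatter) in this assay, so where the two chlorines stand matters and not only that they are present. Set against 2-chlorophenyl, the same group gives a 10-fold lower number from compound 2 to compound 3 (1.02 log units; beyond the scatter), the only large step among these compounds. No measurement shown here accounts for either step. The compounds shown leave open whether methyl, methoxy or trifluoromethyl in place of these chlorines would keep the lower number, and whether the step from compound 1 to compound 3 would hold on another core.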